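A few compounds are considered here, and "the series" means these few. Any claim that something is new, unique, unknown or untested is made for them only; others in the source may bear on it.

The measured compounds and their values:

compound 1 `C=C1C[C@]23C[C@@]1(O)CC[C@H]2c1ccc(OS(=O)(=O)c2ccc(C)cc2)c(C)c1[C@@H]3Cn1cc(-c2ccc(Br)cc2)nn1` — > 20000 nM
compound 2 `C=C1C[C@]23C[C@@]1(O)CC[C@H]2c1ccc(OS(=O)(=O)c2ccc(C)cc2)c(C)c1[C@@H]3Cn1cc(-c2ccc(OC)cc2)nn1` — > 20000 nM
compound 3 `COc1ccc(-c2cn(C[C@H]3c4c(ccc(OS(=O)(=O)c5ccc(C)cc5)c4C)[C@@H]4CC[C@@]5(C)C[C@]43CC5=O)nn2)cc1` — > 20000 nM

All three were tested in a functional assay on SMMC-7721 cells (Homo sapiens) for cytotoxicity, read by MTT assay, with a stated time of 4 days; on this read-out higher numbers stand for weaker inhibition and lower numbers for stronger inhibition. In this assay compound 1 gives > 20000 nM, which is a limit of the assay and not a number. Compound 2 likewise gives > 20000 nM, again a limit. Compound 3 gives > 20000 nM, also a limit. Going by the values given here, every value so far therefore sits at the limit of > 20000 nM in this assay, at which 3 of the 3 values shown sit.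

Compound 1 differs from compound 2 by one change: bromo in place of methoxy on an aromatic carbon. The step this made is a step that the two limits leave unreadable from compound 2 to compound 1, so nothing can be said about whether the bromo or the methoxy group is the better choice here.

Compound 3 is built from the same atoms as compound 2, joined differently; the difference between the two cores is not broken down here.

Compound 4 `Cc1ccc(S(=O)(=O)Oc2ccc3c(c2C)[C@H](Cn2cc(-c4ccc(Br)cc4)nn2)[C@@]24CC(=O)[C@@](C)(CC[C@@H]32)C4)cc1` has not yet been measured. Among the compounds with values here, it differs from compound 3 by bromo in place of methoxy on an aromatic carbon, the same change as the one from compound 2 to compound 1, made at the same place.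

Compound 4 is expected to give 30000 nM, again most likely a limit rather than a number. The step this estimate means, a step that the limit leaves unreadable from compound 3 to compound 4, is expected to be no change at all. That expectation rests on compound 3 giving > 20000 nM, a limit, and on (the limit of > 20000 nM in this assay, at which 3 of the 3 values shown sit); the expected range is 15000 nM to 100000 nM.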

Compound 4, half-maximal inhibitory concentration: > 20000 nM
Compound 4 was reported as a limit (the forecaster's own chance of this, stated with the estimate: 85%); the middle value lies beyond the limit too.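

In this assay compound 4 gives > 20000 nM, which is a limit and not a number. Compound 3 also sits at a limit, so no step can be read for bromo in place of methoxy between compound 3 and compound 4. The compounds shown leave open whether either group or either core affects cytotoxicity at all, because every value is a limit: the limit of > 20000 nM in this assay, at which 4 of the 4 values shown sit.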